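The source may hold more compounds than are shown below. What is called first, only, known or untested is meant among the compounds shown, and "the series" means these compounds.

Measured compounds, with their values in an assay for inhibition of histone acetyltransferase KAT2B (Homo sapiens); a lower number here means a stronger inhibitor, a higher number a weaker inhibitor:
compound 1 `O=c1ccsn1-c1ccccn1`: 19000 nM
compound 2 `CN(C)c1ccc(-n2sccc2=O)cc1`: 5400 nM
compound 3 `O=c1cc(CO)sn1-c1ccccc1`: 109000 nM

Compound 3 stands at the highest of the three numbers in this assay; compound 1 is the nearest, at a lower value, and compound 2 the furthest, also lower, both gaps beyond the scatter. Compound 4 `[N-]=[N+]=NCc1cc(=O)n(-c2ccccc2)s1` differs from compound 3 by azido in place of hydroxy on a saturated chain carbon bound to an aromatic carbon. Among the compounds with values here, no pair of measured compounds differs in one place, so none of them sets the size of this change. The expectation is a step of a 1.4-fold lower number from compound 3 to compound 4 (0.13 log units; within the scatter), that is a small lowering that may well stay within the scatter. Compound 4 is therefore estimated at 80000 nM, with a range from 25000 nM to 250000 nM.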

Compound 4, half-maximal inhibitory concentration: 58000 nM
Compound 4: middle estimate off by 1.4-fold (0.14 log units), on the high side, within the range that was stated.
By their numbers in this assay, from the lowest: compound 2; then compound 1; then compounds 4 and 3 (each within the scatter of the next).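

In this assay, azido in place of hydroxy on a saturated chain carbon bound to an aromatic carbon gives a 1.9-fold lower number from compound 3 to compound 4 (0.27 log units; within the scatter). At this place, then, the hydrogen-bond donor of hydroxy can go and three heavy atoms can replace one with the two values staying within the scatter of each other. No supporting data on hand account for this result. On these data alone, whether an amine, a carboxylic acid or a longer chain at this place would shift the number beyond the scatter remains open.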